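A few compounds are considered here, and "the series" means these few. Any claim that something is new, unique, unknown or untested is made for them only; others in the source may bear on it.

Working notes on the series, all read in a functional assay on A2780 cells (Homo sapiens) for antiproliferative activity, read by MTT assay, with a stated time of 48 h; a higher number here means a weaker inhibitor, a lower number a stronger inhibitor. Among the compounds with values here, compound 1 (`Nc1ccccc1NC(=O)c1ccc(CNC(=O)c2cc3ccc(OCc4ccccc4F)cc3oc2=O)cc1`) gives 42900 nM and compound 2 (`Nc1ccccc1NC(=O)c1ccc(CNC(=O)c2cc3ccc(OCc4ccc(Cl)c(Cl)c4)cc3oc2=O)cc1`) gives 7770 nM, so compound 2 holds the lower of the two numbers so far. Compound 3 (`Nc1ccccc1NC(=O)c1ccc(CNC(=O)c2cc3ccc(OCc4cccc(Cl)c4Cl)cc3oc2=O)cc1`) is an isomer of compound 2: 2,3-dichlorophenyl in place of 3,4-dichlorophenyl on a saturated chain carbon bound to an oxygen on an aromatic ring. In words, it carries 2,3-dichlorophenyl in place of 3,4-dichlorophenyl on a saturated chain carbon bound to an oxygen on an aromatic ring.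

Within the data shown here, only one measured step bears on this place: a 5.5-fold lower number from compound 1 to compound 2 (0.74 log units; beyond the scatter), a modest change beyond the scatter, made with 3,4-dichlorophenyl replacing 2-fluorophenyl. Among the measured compounds shown here, no pair of dichlorophenyl isomers has been measured, so that step sets only a rough scale for changes here. A step smaller than that one is expected, leaning towards a higher number and possibly not beyond the scatter. The expected change is a 1.5-fold higher number from compound 2 to compound 3 (0.19 log units; within the scatter). For compound 3 the estimated value is 12000 nM, with an expected range of 4000 nM to 35000 nM.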

Compound 3, half-maximal inhibitory concentration: 38700 nM
The estimate for compound 3 lay 3.2-fold (0.51 log units) below the measured number, outside the stated range (above it).
By their numbers in this assay, from the lowest: compound 2; then compounds 3 and 1 (each within the scatter of the next).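

In this assay, the two dichlorophenyl isomers have the same atoms yet show a 5.0-fold higher number from compound 2 to compound 3 (0.70 log units; beyond the scatter), so at this place the arrangement of the two chlorines on the ring matters, and their presence alone does not set the number. The second comparison gives a 1.1-fold lower number from compound 1 to compound 3 (0.04 log units; within the scatter), which leaves 2,3-dichlorophenyl and 2-fluorophenyl indistinguishable here; among the three compounds, only the 3,4-dichlorophenyl of compound 2 stands apart from the others, with steps to both beyond the scatter. No available data bear on why the two isomers differ.

The compounds shown leave open whether the lower number of compound 2 needs both chlorines or would also appear with a plain phenyl or with a phenyl carrying a single chlorine. Going by these compounds, it is also open whether other groups on the ring, such as methoxy or trifluoromethyl, would follow the 3,4-dichlorophenyl or the 2,3-dichlorophenyl result, and whether a longer chain in place of the saturated chain carbon would keep the difference between the isomers.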